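The source may report more compounds than this note shows. Statements on the series, on what has been measured and on what is new or still open speak of the compounds shown alone.

Measured in a functional assay on WM1361 cells (Homo sapiens) for inhibition, read by MTT assay, with a stated time of 24 h; a higher number here means a weaker inhibitor, a lower number a stronger inhibitor:
- compound 1 `O=c1oc2ccccc2c(N2CCN(c3cccc(Cl)c3Cl)CC2)c1CO`: 45900 nM
- compound 2 `O=c1oc2ccccc2c(N2CCN(c3ccc(F)cc3)CC2)c1CO`: > 50000 nM

Compound 2 has no number, only a limit of the assay, and the series touches (the limit of > 50000 nM in this assay, at which 1 of the 2 values shown sits). Among the compounds with values here, the one measured step is an at least 1.0-fold higher number from compound 1 to compound 2 (0.03 log units; that floor lies within the scatter), with 4-fluorophenyl in place of 2,3-dichlorophenyl. Compound 3 `COc1ccccc1N1CCN(c2c(CO)c(=O)oc3ccccc23)CC1` has 2-methoxyphenyl in place of 4-fluorophenyl on an amine nitrogen in a ring. With only an at least 1.0-fold higher number from compound 1 to compound 2 (0.03 log units; that floor lies within the scatter) to go on, no change beyond the scatter is expected in this assay. The expected step is an at least 1.1-fold lower number from compound 2 to compound 3 (0.04 log units; that floor lies within the scatter). Compound 3 is estimated at 45000 nM, with an expected range of 20000 nM to 90000 nM.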

Compound 3, half-maximal inhibitory concentration: > 50000 nM
Compound 3 gave a limit, no number; the forecaster's own chance of this, stated with the estimate: 50%; at least 1.1-fold (0.04 log units) between middle value and limit.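

In this assay, 2-methoxyphenyl on the amine nitrogen in a ring gives an at least 1.0-fold higher number from compound 1 to compound 3 (0.03 log units; that floor lies within the scatter). The step between compound 2 and compound 3 cannot be read, as both values are limits. A third phenyl group at this position thus adds no measurable separation, because the series rests at the limit of the assay: the limit of > 50000 nM in this assay, at which 2 of the 3 values shown sit.

As far as these compounds go, whether a carboxylic acid or a longer chain carrying an amine, in place of the phenyl groups at this position, would give a number clearly lower than compound 1 stays open.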